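Methyl for Cyclopropyl on the Amide Nitrogen

This account rests on a few compounds, and the source may have more. Where it says the series, first, only, none or still open, it means among the compounds named here.

Three compounds have been measured in a functional assay on the whole organism with Rattus norvegicus as the target, at a dose of 20 mg/kg by the oral route; a higher number here means more inhibition at the dose given (going by the name of the read-out), a lower number less inhibition:

compound 1, `O=C(/C=C1\CCc2cc(Cl)ccc21)NC1CC1`, gives 29%
compound 2, `O=C(/C=C1\CCc2ccc(F)cc21)NCC1CC1`, gives 21%
compound 3, `NC(=O)/C=C1\CCc2cc(F)cc(F)c21`, gives 55%

Compound 1 holds the second highest of the three numbers. Its nearest neighbour is compound 2, whose value sits within the usual scatter of compound 1, so the two cannot be told apart. Compound 3 lies furthest away, with a value that stands beyond the scatter above compound 1; compound 3 differs from compound 1 in more than one place, so no single change can be read from that gap.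

The compound that follows, compound 4, `CNC(=O)/C=C1\CCc2cc(Cl)ccc21`, departs from compound 1 in one place: methyl in place of cyclopropyl on an amide-type nitrogen. Among the compounds with values here, no pair of measured compounds differs in this one place alone, so the size of such a step is not known from the data. Within the data shown here, the only hint is that compound 3, which carries no substituent on the amide nitrogen, gives 55%, but its ring substitution differs as well.

The step from compound 1 to compound 4 is expected to be small, most likely within the scatter, with a lean toward more inhibition, a number 6 percentage points higher from compound 1 to compound 4 (within the scatter). Compound 4 is therefore estimated at 35%, within a range from 15% to 55%.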

Compound 4, a percentage reported as inhibition, in the whole organism at one dose (the size of the read-out at that dose, not a potency): 44%
For compound 4 the middle estimate is 9 percentage points below the measured one; low and high end bracket the measured number.
By their numbers in this assay, from the lowest: compounds 2 and 1 (each within the scatter of the next); then compound 4; then compound 3.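

Within the data shown here, compound 1 and compound 4 form the first pair in this set that differs in one place alone, so the effect of this change can now be read directly rather than inferred across compounds that also differ elsewhere. In this assay, methyl in place of cyclopropyl on the amide-type nitrogen gives a number 15 percentage points higher from compound 1 to compound 4 (beyond the scatter) and the core of compound 1 stays untouched. The substituent on this nitrogen therefore matters to the read-out at the dose given, and on this core cyclopropyl is not needed to retain inhibition, although nothing at hand gives a reason for the step.

As far as these compounds go, this is a single pair on one core, so it remains open whether methyl in place of cyclopropyl would give a step of similar size with a different ring substitution, such as the fluorine-bearing ones of compound 2 and compound 3. Also open, from the compounds shown here alone, is how this core would respond on the same nitrogen to ethyl, isopropyl or a longer chain, or to a bare amide with no carbon substituent at all.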